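The compounds below may be only part of what the source reports. "The series", "measured", "known", "first", "only" and "open" are said of these compounds alone.

Measured compounds:
- compound 1 `Cn1nc(CN2CCCC2)nc1-c1ccc(C2CC2)cc1` — in an assay on membranes from Jurkat cells for displacement of a labelled ligand from Sigma intracellular receptor 2 (Homo sapiens), read by scintillation counting, with a stated time of 1 h (a lower number here means a stronger inhibitor, a higher number a weaker inhibitor), compound 1 gives 1000 nM
- compound 2 `CC(C)c1ccc(-c2nc(CN3CCCC3)nn2C)cc1` — compound 2 gives 1000 nM
- compound 3 `Cn1nc(CN2CCCC2)nc1-c1ccc(C2(C(F)(F)F)CC2)cc1` — compound 3 gives only a limit, > 1000 nM

Compound 3 thus sits at the weak end of what the assay resolves: its number is a limit rather than a measured value, and it is the one of the three that sits at the limit of > 1000 nM in this assay, at which 1 of the 3 values shown sits. Compound 4 `Cc1ccc(-c2nc(CN3CCCC3)nn2C)cc1` has not been measured; it differs from compound 3 by methyl in place of 1-(trifluoromethyl)cyclopropyl on an aromatic carbon.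

Within the data shown here, two measured steps bear on this. The step of a number no lower from compound 2 to compound 3 (the limit leaves the size open) and the step of a number no lower from compound 1 to compound 3 (the limit leaves the size open) both run toward compound 3 and both end at the limit, so neither shows its size. The step of no change at the digits printed from compound 1 to compound 2 (within the scatter) shows that exchanging two small groups at this position leaves the number where it was. Replacing the largest group with the smallest should at most bring compound 4 back toward where compound 1 and compound 2 stand, though a limit again is possible. Compound 4 is therefore expected to give 1500 nM, within 500 nM to 5000 nM, meaning an estimated step that the limit leaves unreadable from compound 3 to compound 4.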

Compound 4, inhibition constant: > 1000 nM
Compound 4: a limit, no number; the forecaster's own chance of this, stated with the estimate: 40%; the middle value is on the limit's open side.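

In this assay compound 4 gives > 1000 nM, which is a limit of the assay and not a number. Methyl, a single carbon, therefore gives no lower number than the other groups at this position: the data show a number no lower from compound 2 to compound 4 (the limit leaves the size open) and a number no lower from compound 1 to compound 4 (the limit leaves the size open), though neither these steps nor the one between compound 3 and compound 4 can be read for size. Methyl and 1-(trifluoromethyl)cyclopropyl, the groups with the fewest and the most heavy atoms here, both end at the same limit: the limit of > 1000 nM in this assay, at which 2 of the 4 values shown sit.

On these data alone, how far compound 3 and compound 4 lie past that limit remains open, so the two cannot be ordered. Also open, as far as these compounds go, is whether an amine or a carboxylic acid at this position would give a lower number than compound 1 gives, 1000 nM.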